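Isopropoxycarbonyl on the ring nitrogen of a thione core

This account rests on a few compounds, and the source may have more. Where it says the series, first, only, none or still open, it means among the compounds named here.

Measured so far:
compound 1, `COC(=O)C1=C(C)NC(=S)NC1c1cccc([N+](=O)[O-])c1`: 55000 nM
compound 2, `CC1=C(C(=O)OC(C)C)C(c2cccc([N+](=O)[O-])c2)NC(=S)N1`: 10700 nM

In an assay on HEK293 cells for antagonist activity at Voltage-dependent L-type calcium channel subunit alpha-1C (Oryctolagus cuniculus), read by FLIPR (on this read-out lower numbers stand for stronger inhibition and higher numbers for weaker inhibition), compound 1 gives 55000 nM, the highest of the two numbers; the nearest is compound 2, where the step of a 5.1-fold lower number from compound 1 to compound 2 (0.71 log units; beyond the scatter) came from isopropyl in place of methyl on an oxygen next to a carbonyl group. Compound 3, `COC(=O)C1=C(C)NC(=S)N(C(=O)OC(C)C)C1c1cccc([N+](=O)[O-])c1`, differs from compound 1 by isopropoxycarbonyl in place of hydrogen on an amide-type nitrogen in a ring. Among the measured compounds shown here, no measured step touches this ring nitrogen, and the only step known sits elsewhere on the core, so it gives little guidance. A small step is expected for compound 3, a 1.8-fold lower number from compound 1 to compound 3 (0.26 log units; within the scatter). The estimate for compound 3 is 30000 nM, within 8000 nM to 100000 nM.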

Compound 3, half-maximal inhibitory concentration: 170 nM
Estimate against measurement, compound 3: 180-fold (2.25 log units) above, outside the stated range (below it).
By their numbers in this assay, from the lowest: compound 3; then compound 2; then compound 1.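

In this assay, isopropoxycarbonyl in place of hydrogen on the amide-type ring nitrogen gives a 320-fold lower number from compound 1 to compound 3 (2.51 log units; beyond the scatter), a large step. Among the compounds shown here, the only earlier step, on the ester oxygen, was modest at a 5.1-fold lower number from compound 1 to compound 2 (0.71 log units; beyond the scatter), and it said nothing about this ring nitrogen, which now proves a position where the number responds strongly to substitution. No measurement at hand accounts for the size of this step. Going by these compounds, it remains open whether an acetyl, a methoxycarbonyl or a longer alkoxycarbonyl chain on this nitrogen would give a similar step. On these data alone, whether the isopropyl ester of compound 2 would add to this change also remains open.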